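Side-chain hydroxyl placement in a shared-core series

The compounds below may be only part of what the source reports. "The series", "measured", "known", "first", "only" and "open" are said of these compounds alone.

Measured so far:
- compound 1, `CC[C@@H](Nc1nc(NCc2ccccn2)c2ncn(C(C)C)c2n1)C(C)(C)O`: in a functional assay on CH1 cells (Homo sapiens) for inhibition, read by sulforhodamine B assay, with a stated time of 96 h (on this read-out lower numbers stand for stronger inhibition of growth and higher numbers for weaker inhibition of growth), compound 1 reaches only a limit of the assay, > 50000 nM, and no number.
- compound 2, `CCC(O)[C@@H](CC)Nc1nc(NCc2ccccn2)c2ncn(C(C)C)c2n1`: compound 2 gives 27000 nM.
- compound 3, `CC[C@H](Nc1nc(NCc2ccccn2)c2ncn(C(C)C)c2n1)C(C)(C)O`: compound 3 gives 42000 nM.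

Notes. The values of compound 2 and compound 3 lie within the scatter of each other (a 1.6-fold higher number from compound 2 to compound 3 (0.19 log units; within the scatter)), so no order between them is claimed. Compound 1 and compound 3 share every atom and bond; the cores differ only as the two compounds have the same atoms and bonds and differ only in configuration as drawn: 1 of 1 stereo elements differ; a stereocentre at a saturated chain carbon is drawn R in compound 1 and S in compound 3.

The structural change of interest is 1-hydroxypropyl in place of 1-hydroxy-1-methylethyl on a saturated chain carbon bound to a nitrogen on an aromatic ring and a saturated chain carbon. Between compound 1 and compound 2 it made an at least 1.8-fold lower number from compound 1 to compound 2 (0.26 log units; that floor lies within the scatter); because compound 1 sits at a limit (the limit of > 50000 nM in this assay, at which 1 of the 3 values shown sits), only a floor for that step is known, and that floor is within the scatter.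

Not yet measured: compound 4, `CCC(O)[C@H](CC)Nc1nc(NCc2ccccn2)c2ncn(C(C)C)c2n1`. From compound 3 to compound 4 the same change is made, (1-hydroxypropyl in place of 1-hydroxy-1-methylethyl on a saturated chain carbon bound to a nitrogen on an aromatic ring and a saturated chain carbon), at the same place, word for word; the two occurrences are therefore the same change, set once on each of the two configurations as drawn (the fact that compounds 1 and 3 differ only in the configuration as drawn).

For compound 4 the expected step is a 1.4-fold lower number from compound 3 to compound 4 (0.15 log units; within the scatter), placed beside an at least 1.8-fold lower number from compound 1 to compound 2 (0.26 log units; that floor lies within the scatter). That expectation rests on the floor-only size of an at least 1.8-fold lower number from compound 1 to compound 2 (0.26 log units; that floor lies within the scatter). It rests also on compound 2 giving 27000 nM with the same side chain in the other drawn configuration. Compound 4 is thus estimated at 30000 nM, with the expected range running from 12000 nM to 80000 nM.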

Compound 4, concentration for 50% growth inhibition: 33000 nM
The estimate for compound 4 lay 1.1-fold (0.04 log units) below the measured number; the range from low to high includes it.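

In this assay, 1-hydroxypropyl in place of 1-hydroxy-1-methylethyl gives a 1.3-fold lower number from compound 3 to compound 4 (0.10 log units; within the scatter), and on the other drawn configuration only a floor is available, so the two occurrences can be set side by side but not matched in size: the same change on two cores in this assay, an at least 1.8-fold lower number (0.26 log units; that floor lies within the scatter) from compound 1 to compound 2 and a 1.3-fold lower number (0.10 log units; within the scatter) from compound 3 to compound 4; the limit leaves it open whether they differ. Compound 1 reaches only a limit of the assay, > 50000 nM, and not a number: the limit of > 50000 nM in this assay, at which 1 of the 4 values shown sits. The further steps, a 1.2-fold higher number from compound 2 to compound 4 (0.09 log units; within the scatter) and an at least 1.5-fold lower number from compound 1 to compound 4 (0.18 log units; that floor lies within the scatter), are also within the scatter, so the notes show that the change, set on either configuration, produced no step beyond the scatter where a size can be read, but they do not show that it carries from one core to the other with a constant size, nor that it fails to.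

As far as these compounds go, it remains open whether an amine in place of the hydroxyl, or a longer chain on the carbon bearing it, would give a step beyond the scatter in this assay on either configuration. The role of configuration also remains open, since the comparison of compound 2 with compound 4 is not a clean pair of defined stereoisomers: the fact that one of compounds 2 and 4 is drawn with a defined configuration and the other without, at the place where they differ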